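Amino to methyl on a thiadiazole sulfide: a second core

The compounds below may be only part of what the source reports. "The series", "measured", "known", "first", "only" and "open" are said of these compounds alone.

In a functional assay on LM7 cells (Homo sapiens) for cytotoxicity, read by MTT assay, with a stated time of 72 h (on this read-out lower numbers stand for stronger inhibition and higher numbers for weaker inhibition), compound 1 `Cc1nnc(SCc2cc(=O)c3ccccc3o2)s1` reaches only the limit of > 25000 nM. Compound 2 `Nc1nnc(SCc2cc(=O)c3ccccc3o2)s1` likewise gives only the limit of > 25000 nM in this assay. Compound 3 `Nc1nnc(SCc2coc3ccccc3c2=O)s1` shares its atoms with compound 2 but joins them differently; in this assay compound 3 gives 730 nM. The difference between the two cores is not broken down here. The change from compound 2 to compound 1 is methyl in place of amino on an aromatic carbon, and the step that the two limits leave unreadable from compound 2 to compound 1 cannot be read because the limit of > 25000 nM in this assay, at which 2 of the 3 values shown sit, holds both of them. Among the measured compounds shown here, compound 4 `Cc1nnc(SCc2coc3ccccc3c2=O)s1` is not yet measured; it differs from compound 3 by methyl in place of amino on an aromatic carbon, which is the same change as the one from compound 2 to compound 1, made on the core of compound 3 instead. The earlier step gives no readable size, so the expectation for compound 4 rests mainly on the value of compound 3 and on the change taking away one hydrogen-bond donor and one acceptor. The expected step is a 2.1-fold higher number from compound 3 to compound 4 (0.31 log units; beyond the scatter). Compound 4 is therefore estimated at 1500 nM in this assay, within an expected range from 400 nM to 6000 nM.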

Compound 4, half-maximal inhibitory concentration: 430 nM
The estimate for compound 4 lay 3.5-fold (0.54 log units) above the measured number; low and high end bracket the measured number.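

In this assay, the change from 5-amino-1,3,4-thiadiazol-2-yl to 5-methyl-1,3,4-thiadiazol-2-yl on the core of compound 3 gives a 1.7-fold lower number from compound 3 to compound 4 (0.23 log units; within the scatter), so on this core the exchange leaves no difference that can be told from the usual scatter, even though the amino group's hydrogen-bond donor and acceptor are gone. This is a single pair, and it does not show that the change behaves alike on both cores. Compound 1 and compound 2 each stand at a limit of the assay and not at a number, so the step between them cannot be read and offers nothing to set beside the new one: the limit of > 25000 nM in this assay, at which 2 of the 4 values shown sit.

The compounds shown leave open whether an ethyl group, a dimethylamino group or a carboxylic acid in the same place on the core of compound 3 would keep the number in this range. They also leave open whether any group at that place would bring the core of compound 2 to a readable number.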